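Swapping a lactam for an anilino group: what happens to solubility

A few compounds are considered here, and "the series" means these few. Any claim that something is new, unique, unknown or untested is made for them only; others in the source may bear on it.

Measured compounds:
Compound 1 `Cc1ncccc1-c1cnc(NCc2c(F)ccc3c2CCO3)c2nn(CC#N)c(=O)n12` gives 4000 nM
Compound 2 `CC1(C)CC(=O)N(c2cnc(NCc3c(F)ccc4c3CCO4)n3cnnc23)C1` gives 57000 nM
Compound 3 `Cc1nc(C(=O)N(C)C)ccc1-c1cnc(NCc2c(F)ccc3c2CCO3)c2cn[nH]c(=O)c12` gives 403000 nM

These three values come from a physicochemical assay for solubility, read by LC-MS, in phosphate buffer, with a stated time of 24 h, at pH 7.4; on this read-out higher numbers stand for higher solubility and lower numbers for lower solubility. Compound 2 sits in the middle of the three: compound 3 gives a higher number, and compound 1 a lower one, and both gaps lie beyond the scatter of repeated measurements. The three compounds differ in more than one place, so no single structural change can be tied to any of these gaps.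

Compound 4 `Fc1ccc2c(c1CNc1ncc(Nc3ccccc3)c3nncn13)CCO2` has not yet been measured in this assay. It differs from compound 2 in one place: anilino in place of 4,4-dimethyl-2-oxopyrrolidin-1-yl on an aromatic carbon. A ring that contained a carbonyl and no hydrogen-bond donor is replaced by a carbon-only aromatic ring that carries one donor.

Within the data shown here, with no step between measured compounds to lean on, the expectation rests on compound 2 alone. Compound 4 is expected to give a lower number than compound 2, by a step of a 3.8-fold lower number from compound 2 to compound 4 (0.58 log units; beyond the scatter), beyond the usual scatter but not by a large margin. The estimate for compound 4 in this assay is 15000 nM, with a range from 3000 nM to 60000 nM.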

Compound 4, solubility: 3000 nM
Beside the measured number, compound 4's estimate is 5.0-fold (0.70 log units) above it; low and high end bracket the measured number.
By their numbers in this assay, from the lowest: compounds 4 and 1 (each within the scatter of the next); then compound 2; then compound 3.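

In this assay, among these compounds, this is the first comparison of two compounds that differ in one place, and it gives a large change: a 19-fold lower number from compound 2 to compound 4 (1.28 log units; beyond the scatter). The group on this aromatic carbon, in the six-membered aromatic ring with 2 nitrogen, therefore matters a great deal for this read-out: replacing 4,4-dimethyl-2-oxopyrrolidin-1-yl with anilino moves the number well beyond the scatter of repeated measurements. This single step changes several things at once, as a non-aromatic ring with a carbonyl gives way to a carbon-only aromatic ring with a hydrogen-bond donor, and nothing measured here explains the fall or shows which of these changes accounts for it.

As far as these compounds go, what stays open is how other groups at this position would compare, such as a morpholine ring, a methylated anilino group, or an anilino ring carrying a carboxylic acid. It is also unknown whether the same swap would shift the number by a similar amount on the different cores of compound 1 and compound 3, so this one step cannot yet be treated as a general rule.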